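Swapping the group on the carbonyl of compound 2

This account rests on a few compounds, and the source may have more. Where it says the series, first, only, none or still open, it means among the compounds named here.

In a functional assay on PC-3 cells (Homo sapiens) for inhibition, read by sulforhodamine B assay, with a stated time of 72 h (a higher number here means a weaker inhibitor, a lower number a stronger inhibitor), compound 1 (`Nc1sc(-c2ccc(Cl)cc2)c(-c2ccc(Cl)cc2)c1C(=O)NC1CCCCC1`) gives 7300 nM and compound 2 (`Nc1sc(-c2ccc(Cl)cc2)c(-c2ccc(Cl)cc2)c1C(=O)NC1CCC(O)CC1`) gives 5670 nM and these two values sit within the usual scatter of each other. Compound 3 (`CN1CCN(C(=O)c2c(N)sc(-c3ccc(Cl)cc3)c2-c2ccc(Cl)cc2)CC1`) carries 4-methylpiperazin-1-yl in place of (4-hydroxycyclohexyl)amino on a carbonyl carbon. Going by the values given here, the one measured step, a 1.3-fold lower number from compound 1 to compound 2 (0.11 log units; within the scatter) (hydroxy in place of hydrogen on a saturated ring carbon), stays within the scatter. Among the compounds with values here, it bears only loosely on the new change: it alters the group that now leaves, and no measured compound carries 4-methylpiperazin-1-yl. On this thin evidence no step beyond the scatter is expected in this assay and the estimated step is a 1.1-fold higher number from compound 2 to compound 3 (0.02 log units; within the scatter) with real room in either direction. For compound 3 the expected value is 6000 nM (2000 nM to 20000 nM as the estimated range).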

Compound 3, half-maximal inhibitory concentration: 13100 nM
Compound 3: middle estimate off by 2.2-fold (0.34 log units), on the low side; measured number inside the range.
By their numbers in this assay, from the lowest: compounds 2, 1 and 3 (each within the scatter of the next, the first and the last beyond it).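

Changing the group on this carbonyl carbon can move the reading in this assay beyond the scatter, though only modestly: the swap to 4-methylpiperazin-1-yl gives (a 2.3-fold higher number from compound 2 to compound 3 (0.36 log units; beyond the scatter)), the only step among these compounds to pass that limit. Measured against the cyclohexylamino group of compound 1, the same kind of swap gives (a 1.8-fold higher number from compound 1 to compound 3 (0.25 log units; within the scatter)), which stays within the scatter, so the conclusion depends on which amide serves as the reference. Nothing measured here bears on why the reading shifts.

From the compounds shown here alone, it remains open whether morpholin-4-yl or piperidin-1-yl on the same carbonyl carbon would read closer to compound 2 or to compound 3. Also unsettled is whether the methyl group on the piperazine ring matters, which a piperazin-1-yl group carrying hydrogen there would test.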